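The source may hold more compounds than are shown below. What is called first, only, known or untested is meant among the compounds shown, and "the series" means these compounds.

Measured in a functional assay on CEM-DNR-bulk cells (Homo sapiens), read by MTT assay, with a stated time of 72 h (a lower number here means a stronger inhibitor, a higher number a weaker inhibitor), each value being a limit of the assay and not a number:

Compound 1 `Nc1nc(N)c2c(-c3ccco3)cn([C@@H]3O[C@H](CO)[C@@H](O)[C@H]3O)c2n1`: > 20000 nM
Compound 2 `Nc1nc(N)c2c(-c3cc4ccccc4o3)cn([C@@H]3O[C@H](CO)[C@@H](O)[C@H]3O)c2n1`: > 20000 nM
Compound 3 `Cc1nc(N)c2c(-c3ccco3)cn([C@@H]3O[C@H](CO)[C@@H](O)[C@H]3O)c2n1`: > 20000 nM

Compound 3 gives > 20000 nM in this assay, which is a limit and not a number. Its standing is no different from that of the other two compounds, and the only firm finding so far is the limit of > 20000 nM in this assay, at which 3 of the 3 values shown sit.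

The step under consideration leads to compound 4 `Cc1nc(N)c2c(-c3ccccc3)cn([C@@H]3O[C@H](CO)[C@@H](O)[C@H]3O)c2n1`, and the change is phenyl in place of furan-2-yl on an aromatic carbon. Phenyl thus takes the place of furan-2-yl on an aromatic carbon, while the rest of compound 3 stays the same.

Among the measured compounds shown here, two measured steps bear on this change. The closer in kind is a step that the two limits leave unreadable from compound 1 to compound 2, which also replaces furan-2-yl with another aromatic group. The other is a step that the two limits leave unreadable from compound 1 to compound 3, with methyl in place of amino. Both ends of each step are limits, so neither step has a readable size and neither gives a direction.

With no measured number in the series, no step beyond the scatter is expected in this assay. The estimated change is a number no higher from compound 3 to compound 4 (the limit leaves the size open), and a further limit is the likeliest report. Compound 4 is expected at an estimated 20000 nM, with an expected range of 9000 nM to 40000 nM.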

Compound 4, half-maximal inhibitory concentration: > 20000 nM
Compound 4: no number, only a limit (the forecaster's own chance of this, stated with the estimate: 85%); the middle value sits exactly at the limit.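

In this assay compound 4 gives > 20000 nM, a limit of the assay and not a number. Compound 3 also stands at a limit, and the step from it to compound 4 cannot be read. The compounds shown leave open whether phenyl in place of furan-2-yl changes anything in this assay, and the one firm finding remains: the limit of > 20000 nM in this assay, at which 4 of the 4 values shown sit.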